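Cyclopentyl for Phenyl on the Amide Nitrogen of Compound 3

The compounds below may be only part of what the source reports. "The series", "measured", "known", "first", "only" and "open" are said of these compounds alone.

Compound 1 `C#CCn1cc(C(=O)NC(CC(=O)Nc2ccccc2)c2ccccc2)c(=O)c2cc(F)c(Cl)nc21`: 9300 nM
Compound 2 `C#CCn1cc(C(=O)NC(CC(=O)NC2CCCC2)c2ccccc2)c(=O)c2cc(F)c(Cl)nc21`: 2000 nM
Compound 3 `C#CCn1cc(C(=O)NC(CC(=O)Nc2ccccc2)c2ccccc2)c(=O)c2ccc(Cl)nc21`: 4000 nM

In a functional assay on HBL-100 cells (Homo sapiens) for cytotoxicity, read by MTT assay, with a stated time of 72 h (on this read-out lower numbers stand for stronger inhibition and higher numbers for weaker inhibition), compound 3 gives the second highest of the three numbers; compound 2 sits within the scatter of it, while compound 1 lies beyond it (a 2.3-fold lower number from compound 1 to compound 3 (0.37 log units; beyond the scatter)). Compound 4 `C#CCn1cc(C(=O)NC(CC(=O)NC2CCCC2)c2ccccc2)c(=O)c2ccc(Cl)nc21` differs from compound 3 in one place: cyclopentyl in place of phenyl on an amide-type nitrogen. The same change has been seen once, in the pair with the fluoro present, where it gave a 4.7-fold lower number from compound 1 to compound 2 (0.67 log units; beyond the scatter). Within the data shown here, that one step is the only guide, so a step of similar size and direction is expected here, a 4.4-fold lower number from compound 3 to compound 4 (0.65 log units; beyond the scatter). Compound 4 is therefore estimated at 900 nM in this assay, within a range of 400 nM to 2200 nM.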

Compound 4, half-maximal inhibitory concentration: 3200 nM
Beside the measured number, compound 4's estimate is 3.6-fold (0.55 log units) below it, and the stated range ends below it.
By their numbers in this assay, from the lowest: compounds 2, 4 and 3 (each within the scatter of the next); then compound 1.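

Without the fluoro, cyclopentyl in place of phenyl on an amide-type nitrogen gives only a 1.3-fold lower number from compound 3 to compound 4 (0.10 log units; within the scatter) in this assay, so the larger step seen with the fluoro present does not carry over to the core of compound 3: the same change on two cores in this assay, a 4.7-fold lower number (0.67 log units; beyond the scatter) from compound 1 to compound 2 and a 1.3-fold lower number (0.10 log units; within the scatter) from compound 3 to compound 4, 3.7-fold (0.57 log units) apart, beyond the scatter of two such steps. Hydrogen in place of fluoro likewise depends on the amide group, giving a 1.6-fold higher number from compound 2 to compound 4 (0.20 log units; within the scatter) with cyclopentyl, unlike the step seen with phenyl: the same change on two cores in this assay, a 2.3-fold lower number (0.37 log units; beyond the scatter) from compound 1 to compound 3 and a 1.6-fold higher number (0.20 log units; within the scatter) from compound 2 to compound 4, 3.7-fold (0.57 log units) apart, beyond the scatter of two such steps. The two places therefore do not act independently in these four compounds.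

From the compounds shown here alone, whether this dependence holds for other groups on that nitrogen, such as cyclohexyl or benzyl, or for methoxy in place of fluoro on the aromatic carbon, stays open.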